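The source may report more compounds than this note shows. Statements on the series, on what has been measured and on what is new or still open speak of the compounds shown alone.

Compound 1 `CC(C)(C)[C@@]1(c2ccccc2)OCC[C@@H](CCN)O1`, compound 2 `C[C@@]1(c2ccccc2)OCC[C@@H](CCN)O1` and compound 3 `CCC[C@]1(c2ccccc2)OCC[C@H](CCN)O1` share one core and differ only in the group on a saturated ring carbon. In an assay on brain for displacement of a labelled ligand from Sigma non-opioid intracellular receptor 1 (Cavia porcellus) (a higher number here means a weaker inhibitor, a lower number a stronger inhibitor), compound 1 gives > 10000 nM, which is a limit of the assay and not a number. In this assay compound 2 gives > 10000 nM, also a limit. In this assay compound 3 gives > 10000 nM, again a limit. The step that the two limits leave unreadable from compound 1 to compound 2 cannot be read because of the limit of > 10000 nM in this assay, at which 3 of the 3 values shown sit. Compound 4 `CCC[C@@]1(c2ccccc2)OCC[C@@H](CCN)O1` differs from compound 3 as follows: the two compounds have the same atoms and bonds and differ only in configuration as drawn: 2 of 2 stereo elements differ (all stereocentres are inverted: mirror images); a stereocentre at a saturated ring carbon is drawn S in compound 3 and R in compound 4; a stereocentre at a saturated ring carbon is drawn S in compound 3 and R in compound 4. Among the measured compounds shown here, no measured step bears on inverting both stereocentres, and none of the measured pairs yields a readable number. Compound 4 is therefore expected to sit near 20000 nM, with a range from 5000 nM to 100000 nM. That expectation means a step that the limit leaves unreadable from compound 3 to compound 4.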

Compound 4, inhibition constant: > 10000 nM
Compound 4 ended at the assay's limit (the forecaster's own chance of this, stated with the estimate: 75%); the middle value is on the limit's open side.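

No new step can be read between compound 4 and compound 1, compound 2 or compound 3, because each value is a limit and not a number: the limit of > 10000 nM in this assay, at which 4 of the 4 values shown sit.

As far as these compounds go, whether the mirror images compound 3 and compound 4 differ at all in this assay stays open.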